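This account rests on a few compounds, and the source may have more. Where it says the series, first, only, none or still open, it means among the compounds named here.

Compound 1 `N#Cc1ccc(Cn2c(=O)n(C3OC(CO)[C@@H](O)[C@H]3O)c3nc(N)nc(O)c32)cc1`: 50%
Compound 2 `NC(=O)Cn1c(=O)n(C2OC(CO)[C@@H](O)[C@H]2O)c2nc(N)nc(O)c21`: 32%

Among the compounds with values here, in a functional assay on the whole organism (B cells) with Mus musculus as the target (on this read-out higher numbers stand for larger maximal responses and lower numbers for smaller maximal responses), compound 2 gives the lower of the two numbers measured so far, with compound 1 standing above it. Compound 3 `Nc1nc(O)c2c(n1)n(C1OC(CO)[C@@H](O)[C@H]1O)c(=O)n2Cc1ccc([N+](=O)[O-])cc1` differs from compound 2 in one place: 4-nitrophenyl in place of carbamoyl on a saturated chain carbon bound to an aromatic nitrogen. Within the data shown here, the only measured step that bears on this change is a number 18 percentage points lower from compound 1 to compound 2 (beyond the scatter), where an aromatic ring on that chain carbon gave way to carbamoyl. Compound 3 brings an aromatic ring back to the same place, so a step of about that size upward is expected: a number 16 percentage points higher from compound 2 to compound 3 (beyond the scatter). Compound 3 is therefore estimated at 48%, within a range from 32% to 64%.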

Compound 3, largest response reached (reported as maximal response), in percent of the reference or control that the assay uses: 147%
For compound 3 the middle estimate is 99 percentage points below the measured one; measured number above the stated range.
By their numbers in this assay, from the lowest: compound 2; then compound 1; then compound 3.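

Swapping carbamoyl for 4-nitrophenyl gives a number 115 percentage points higher from compound 2 to compound 3 (beyond the scatter), far more than the earlier step suggested. Compounds 1 and 3 both carry an aromatic ring at this position, yet nitro in place of cyano on an aromatic carbon gives a number 97 percentage points higher from compound 1 to compound 3 (beyond the scatter) in this assay, so the ring's presence alone does not set the response and the group on it matters greatly. No available evidence accounts for this gap between nitro and cyano.

As far as these compounds go, how an amine or a carboxylic acid would fare in place of the nitro group remains open. So does the effect of a longer chain joining the ring to the aromatic nitrogen.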